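The source may hold more compounds than are shown below. What is called first, only, known or untested is meant among the compounds shown, and "the series" means these compounds.

Results in a functional assay on HO8910 cells (Homo sapiens) for inhibition, read by MTT assay, with a stated time of 24 h, tested at 0.1 ug/mL; on this read-out higher numbers stand for more inhibition of growth at the one concentration tested and lower numbers for less inhibition of growth:
Compound 1 `CC(=O)SCCC(CCCCC(=O)O)SC(C)=O`: "not active" (no number reported)
Compound 2 `CC(=O)SCCC(CCCCC(=O)Nc1ccccc1)SC(C)=O`: 8.33%
Compound 3 `CC(=O)SCCC(CCCCC(=O)Nc1ccccc1Cl)SC(C)=O`: 2.48%

Only two of these compounds carry numbers, and compound 3 lies within the scatter of compound 2. Among the compounds with values here, the single measured step between them is a number 5.9 percentage points lower from compound 2 to compound 3 (within the scatter). Compound 1 offers no number for comparison.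

The next compound to be tested is compound 4 `CC(=O)SCCC(CCCCC(=O)Nc1cccc(Cl)c1)SC(C)=O`, which has the same atoms as compound 3, joined differently: 3-chlorophenyl in place of 2-chlorophenyl on an amide-type nitrogen. In words, 3-chlorophenyl takes the place of 2-chlorophenyl on an amide-type nitrogen. Within the data shown here, no measured pair compares these two groups directly. The closest evidence is the step that put chloro in place of hydrogen on an aromatic carbon, and that step stayed within the scatter. With so little to go on, no shift beyond the scatter is expected in this assay. The expected step is a number 2.5 percentage points higher from compound 3 to compound 4 (within the scatter). For compound 4 the estimated value is 5%, with an expected range from 0% to 13%.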

Compound 4, percent growth inhibition at one concentration: 0.27%
Compound 4: middle estimate off by 4.7 percentage points, on the high side, within the range that was stated.
By their numbers in this assay, from the lowest: compounds 4, 3 and 2 (each within the scatter of the next).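

In this assay, within the data shown here, the chlorine's placement is now tested directly for the first time: 3-chlorophenyl in place of 2-chlorophenyl on the amide-type nitrogen gives a step within the scatter (a number 2.2 percentage points lower from compound 3 to compound 4 (within the scatter)). Chloro in place of hydrogen on an aromatic carbon now has a second reading, and this also stays within the scatter (a number 8.1 percentage points lower from compound 2 to compound 4 (within the scatter)), so neither chlorophenyl isomer separates from the unsubstituted phenyl amide of compound 2 on this read-out. No measured evidence bears on these small steps.

Still open, going by these compounds, is whether 4-chlorophenyl on the same amide-type nitrogen would also stay within the scatter of compound 2. On these data alone, it is equally open whether a methoxy group or an amine on the aromatic ring in place of chloro would give a step beyond it.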